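The compounds below may be only part of what the source reports. "The series", "measured", "known", "first", "only" and "open" are said of these compounds alone.

The measured compounds in an ADME assay on Akata cells (Homo sapiens) for cytotoxicity, with a stated time of 7 days; on this read-out higher numbers stand for lower toxicity in this test and lower numbers for higher toxicity in this test:
Compound 1, `CN(C)c1nc(N)nc2c1ncn2/C=C1/CC1(CO)CO`, gives > 24000 nM, a limit of the assay.
Compound 2, `Nc1nc(NC2CC2)c2ncn(/C=C3/CC3(CO)CO)c2n1`, gives > 20000 nM, a limit of the assay.
Compound 3, `CCCCCOc1nc(N)nc2c1ncn2/C=C1/CC1(CO)CO`, gives > 20000 nM, a limit of the assay.

Compound 1 therefore stands only at a limit in this assay, and no number sets it against the others. Compound 4, `Nc1nc(SCc2ccccc2)c2ncn(/C=C3/CC3(CO)CO)c2n1`, differs from compound 1 in one place: benzylsulfanyl in place of dimethylamino on an aromatic carbon. The steps that touch the same position are a step that the two limits leave unreadable from compound 1 to compound 2 and a step that the two limits leave unreadable from compound 1 to compound 3; compounds 2 and 3 sit at the limit of > 20000 nM in this assay, at which 2 of the 3 values shown sit, while compound 1 sits at the limit of > 24000 nM in this assay, at which 1 of the 3 values shown sits, so neither step has a readable size. Nothing measured points to a change beyond the scatter in either direction, and a limit is expected once more. Compound 4 is expected to give 24000 nM, between 10000 nM and 60000 nM, an expected step of a number no higher from compound 1 to compound 4 (the limit leaves the size open).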

Compound 4, half-maximal cytotoxic concentration: > 20000 nM
Compound 4 ended at the assay's limit; the forecaster's own chance of this, stated with the estimate: 75%; the middle value lies beyond the limit too.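

Compound 4 stands at a limit of the assay, as do compound 1, compound 2 and compound 3, so none of its steps to them can be read. The compounds shown leave open whether changing this group alters the read-out in this assay at all.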